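Iodo on the styryl aryl ring of compound 3

The source may hold more compounds than are shown below. What is called first, only, known or untested is meant among the compounds shown, and "the series" means these compounds.

Measured so far in a functional assay on PC-3 cells (Homo sapiens) for antiproliferative activity, read by sulforhodamine B assay, with a stated time of 3 days; on this read-out lower numbers stand for an effect already at smaller amounts and higher numbers for an effect only at larger amounts of compound:
compound 1 `CCCC1=C(OC)C(CCC)(CCC)C(=O)/C(=C(O)\C=C\c2ccc(I)cc2)C1=O`: 2.8 uM
compound 2 `CCCC1=C(OCCC(C)C)C(CCC)(CCC)C(=O)/C(=C(O)\C=C\c2ccccc2)C1=O`: 17 uM
compound 3 `CCCOC1=C(CCC)C(=O)/C(=C(O)/C=C/c2ccccc2)C(=O)C1(CCC)CCC`: 8.6 uM

In this assay compound 3 gives 8.6 uM, the second highest of the three numbers; compound 2 gives 17 uM and compound 1 gives 2.8 uM. For the measured compounds named here, the only single-place step measured, a 2.0-fold lower number from compound 2 to compound 3 (0.30 log units; within the scatter), concerns the ether chain and not the aryl ring. Compound 4 `CCCOC1=C(CCC)C(=O)/C(=C(O)/C=C/c2ccc(I)cc2)C(=O)C1(CCC)CCC` differs from compound 3 by iodo in place of hydrogen on an aromatic carbon. Going by the values given here, no measured step isolates this change; compound 1 carries the iodo group but also differs from compound 3 in where the ether sits, so its value shows only that an iodo-bearing member gives the lowest number of the three. Compound 4 is therefore expected to give 5 uM (range 2 uM to 12 uM). The expected step of a 1.7-fold lower number from compound 3 to compound 4 (0.24 log units; within the scatter) is modest and may not reach beyond the scatter.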

Compound 4, concentration for half-maximal effect: 9.6 uM
Compound 4: middle estimate off by 1.9-fold (0.28 log units), on the low side, and the stated range covers the measured number.
By their numbers in this assay, from the lowest: compound 1; then compounds 3, 4 and 2 (each within the scatter of the next).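

In this assay, for the compounds shown here, iodo in place of hydrogen on the aromatic carbon gives a 1.1-fold higher number from compound 3 to compound 4 (0.05 log units; within the scatter) on the first reading that isolates this change, so the styryl ring position shows no shift beyond the scatter. Among the iodo-bearing members, the ether side does separate the numbers: ethyl in place of hydrogen on the saturated chain carbon bound to an oxygen on an unsaturated carbon corresponds to a 3.4-fold higher number from compound 1 to compound 4 (0.54 log units; beyond the scatter) in reverse. Nothing at hand accounts for either step.

Open, as far as these compounds go, is whether an amine or a carboxylic acid on the same aromatic carbon would move the number beyond the scatter. Also open, from the compounds shown here alone, is how a longer chain on the ether oxygen behaves with iodo present.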